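The source may report more compounds than this note shows. Statements on the series, on what has been measured and on what is new or still open speak of the compounds shown alone.

In a functional assay on HepG2 cells (Homo sapiens) for cytotoxicity, read by MTT assay, with a stated time of 24 h (on this read-out higher numbers stand for weaker inhibition and lower numbers for stronger inhibition), three compounds with a shared core have been measured: compound 1 `COc1cc(/C=C2\CN(C)C/C(=C\c3ccc(Cl)cc3)C2=O)cc(OC)c1` gives 5950 nM, compound 2 `COc1cc(/C=C2\CN(C)C/C(=C\c3ccc(Cl)cc3Cl)C2=O)cc(OC)c1` gives 6250 nM and compound 3 `COc1cc(/C=C2\CN(C)C/C(=C\c3ccc(Cl)c(Cl)c3)C2=O)cc(OC)c1` gives 3840 nM. Compound 2 stands level with both others, as the steps show: a 1.1-fold higher number from compound 1 to compound 2 (0.02 log units; within the scatter) and a 1.6-fold lower number from compound 2 to compound 3 (0.21 log units; within the scatter). Compound 4 `COc1cc(/C=C2\CN(C)C/C(=C\c3ccc(Cl)cc3Cl)C2=O)cc(OC)c1OC` has methoxy in place of hydrogen on an aromatic carbon. For the measured compounds named here, no measured step adds a methoxy. The closest guides add a chloro in place of hydrogen on an aromatic carbon, and they are small: a 1.1-fold higher number from compound 1 to compound 2 (0.02 log units; within the scatter) and a 1.5-fold lower number from compound 1 to compound 3 (0.19 log units; within the scatter). A step beyond the scatter is therefore not expected in this assay. The expected step is a 1.3-fold lower number from compound 2 to compound 4 (0.10 log units; within the scatter). For compound 4 the estimated value is 5000 nM, with an expected range from 2500 nM to 10000 nM.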

Compound 4, half-maximal inhibitory concentration: 8800 nM
Compound 4: middle estimate off by 1.8-fold (0.25 log units), on the low side, and the stated range covers the measured number.
By their numbers in this assay, from the lowest: compounds 3, 1, 2 and 4 (each within the scatter of the next, the first and the last beyond it).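

In this assay, for the compounds shown here, this is the first view of a change on the methoxy-bearing ring, as the earlier steps changed only chloro groups elsewhere. Placing a methoxy ortho to two methoxy groups and para to a large group gives a step within the scatter (a 1.4-fold higher number from compound 2 to compound 4 (0.15 log units; within the scatter)), so this position tolerates the added group in this assay. Nothing available explains the size of this step.

As far as these compounds go, whether a hydroxy group or an amine at this position would give a step beyond the scatter remains open. So does whether a methoxy here would act alike in compound 1 or compound 3.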